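This account rests on a few compounds, and the source may have more. Where it says the series, first, only, none or still open, it means among the compounds named here.

Two ureas built on the shared core are compared in an assay on microsomes from intestine for inhibition of acyl-CoA:cholesterol acyltransferase (Oryctolagus cuniculus); a lower number here means a stronger inhibitor, a higher number a weaker inhibitor. Compound 1 `O=C(Nc1c(F)cc(F)cc1F)N(Cc1ccc(-c2ccccn2)cc1)C1CCCCCC1` gives 25 nM. Compound 2 `Cc1cc(C)c(NC(=O)N(Cc2ccc(-c3cn[nH]c3)cc2)C2CCCCCC2)c(C)c1` gives 270 nM, the higher of the two numbers and beyond the scatter from compound 1. Compound 3 `Cc1cc(C)c(NC(=O)N(Cc2ccc(-n3nccn3)cc2)C2CCCCCC2)c(C)c1` differs from compound 2 in one place: 2H-1,2,3-triazol-2-yl in place of 1H-pyrazol-4-yl on an aromatic carbon, with 2H-1,2,3-triazol-2-yl in place of 1H-pyrazol-4-yl on an aromatic carbon. Going by the values given here, no measured pair shows this exchange, so the step from compound 2 to compound 3 is expected to be small, a 1.4-fold lower number from compound 2 to compound 3 (0.13 log units; within the scatter), not clearly beyond the scatter. Compound 3 is therefore estimated at 200 nM, with a range from 60 nM to 700 nM.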

Compound 3, half-maximal inhibitory concentration: 130 nM
Compound 3: middle estimate off by 1.5-fold (0.19 log units), on the high side, within the range that was stated.
By their numbers in this assay, from the lowest: compound 1; then compound 3; then compound 2.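

In this assay, the position para to a large group accepts a change of five-membered ring, and 2H-1,2,3-triazol-2-yl in place of 1H-pyrazol-4-yl gives a 2.1-fold lower number from compound 2 to compound 3 (0.32 log units; beyond the scatter), a modest step just beyond the scatter. The entering ring has no hydrogen-bond donor and the leaving ring has one, but a single pair cannot show whether that difference matters. Nothing measured here explains the step. Still open, going by these compounds, is how an amine or a carboxylic acid on this ring would compare, and whether the same exchange gives a similar step on a different urea.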